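Chloro added to the urea aryl of compound 2

The source may report more compounds than this note shows. Statements on the series, on what has been measured and on what is new or still open speak of the compounds shown alone.

Compound 1 `COc1cc(-c2nn(-c3cccc(NC(=O)c4cccc(C(F)(F)F)c4)c3)cc2-c2ccncc2)ccc1Cl` and compound 2 `COc1cc(-c2nn(-c3cccc(NC(=O)Nc4cccc(C(F)(F)F)c4)c3)cc2-c2ccncc2)ccc1Cl` share one core and differ only in the link joining the carbonyl to the 3-(trifluoromethyl)phenyl group. In a functional assay on OVCAR-5 cells (Homo sapiens) for inhibition, read by sulforhodamine B assay, with a stated time of 48 h (a higher number here means that more compound is tolerated, a lower number that less compound is tolerated), compound 1 reaches only the limit of > 50000 nM. In this assay compound 2 likewise reaches only the limit of > 50000 nM. The step that the two limits leave unreadable from compound 1 to compound 2 is therefore unreadable. Compound 2 thus stands at the limit, with no number of its own; both measured values sit at the limit of > 50000 nM in this assay, at which 2 of the 2 values shown sit.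

Compound 3 `COc1cc(-c2nn(-c3cccc(NC(=O)Nc4ccc(Cl)c(C(F)(F)F)c4)c3)cc2-c2ccncc2)ccc1Cl` differs from compound 2 by chloro in place of hydrogen on an aromatic carbon. For the measured compounds named here, no measured step bears on this change: the single measured step, from compound 1 to compound 2, gives no size in either direction, and nothing shows how a chloro entering on that ring shifts the result. There is no basis for expecting a step beyond the scatter in this assay. The step from compound 2 to compound 3 is estimated as a number no higher from compound 2 to compound 3 (the limit leaves the size open). Compound 3 is expected to give 50000 nM in this assay, between 20000 nM and 100000 nM, most likely again reported only as a limit.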

Compound 3, concentration lethal to 50% of the cells: > 32500 nM
Compound 3: only a limit was reported; the forecaster's own chance of this, stated with the estimate: 80%; the middle value does not contradict the limit.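

Compound 3 gives only a limit in this assay, > 32500 nM, and with compound 1 and compound 2 also reported only as limits, no step among these three compounds can be read. The compounds shown leave open whether the urea link or chloro in place of hydrogen changes the read-out at all.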